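The compounds below may be only part of what the source reports. "The series", "measured", "known", "first", "only" and "open" are said of these compounds alone.

Measured compounds in an assay on membranes from HEK293 cells for displacement of a labelled ligand from Type-2 angiotensin II receptor (Homo sapiens), read by radioligand binding; a lower number here means a stronger inhibitor, a higher number a weaker inhibitor:
Compound 1, `CCCCOC(=O)NS(=O)(=O)c1ccc(CCC)cc1-c1ccc(Cn2c(C3CCCCC3)nc3ccccc32)cc1`: 130 nM
Compound 2, `CCCCOC(=O)NS(=O)(=O)c1ccc(CCC)cc1-c1ccc(Cn2c(CCCC)nc3ccccc32)cc1`: 9.2 nM
Compound 3, `CCCCOC(=O)NS(=O)(=O)c1ccc(CCC)cc1-c1ccc(Cn2c(Cc3ccccc3)nc3ccccc32)cc1`: 15 nM

Compound 3 stands second highest of the three numbers in this assay. Its nearest neighbour is compound 2, and the gap a 1.6-fold higher number from compound 2 to compound 3 (0.21 log units; within the scatter) lies within the scatter, so the two cannot be ordered. Compound 1 lies furthest away, with an 8.7-fold lower number from compound 1 to compound 3 (0.94 log units; beyond the scatter).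

Compound 4, `CCCCOC(=O)NS(=O)(=O)c1ccc(CCC)cc1-c1ccc(Cn2c(C3CCC3)nc3ccccc32)cc1`, has not yet been measured. It differs from compound 3 in one place: cyclobutyl in place of benzyl on an aromatic carbon. Among the measured compounds shown here, two measured steps bear on this change, both starting from compound 1, which carries cyclohexyl at that position: a 14-fold lower number from compound 1 to compound 2 (1.15 log units; beyond the scatter) and an 8.7-fold lower number from compound 1 to compound 3 (0.94 log units; beyond the scatter). Compound 1, with cyclohexyl, gives the highest number of the three, while butyl in compound 2 and benzyl in compound 3 give lower numbers. Compound 4 brings back a non-aromatic ring of carbon only at that position, though one of four heavy atoms rather than six. An upward step in this assay is therefore expected from compound 3, yet one smaller than the gap between compound 3 and compound 1. Compound 4 is expected to give 30 nM, within a range from 10 nM to 90 nM. The expected step is a 2.0-fold higher number from compound 3 to compound 4 (0.30 log units; within the scatter).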

Compound 4, inhibition constant: 12 nM
Compound 4: middle estimate off by 2.5-fold (0.40 log units), on the high side; the range from low to high includes it.
By their numbers in this assay, from the lowest: compounds 2, 4 and 3 (each within the scatter of the next); then compound 1.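

In this assay, a non-aromatic ring of carbon only at this position, on the aromatic carbon between two ring nitrogen atoms, does not by itself bring the high number of compound 1: the cyclobutyl of compound 4 parts clearly from the cyclohexyl of compound 1 (an 11-fold lower number from compound 1 to compound 4 (1.03 log units; beyond the scatter)). The cyclobutyl group cannot be told apart from benzyl (a 1.3-fold lower number from compound 3 to compound 4 (0.10 log units; within the scatter)) or from butyl (a 1.3-fold higher number from compound 2 to compound 4 (0.12 log units; within the scatter)), so a ring of four carbons, a benzyl group and an open butyl chain all fall within the scatter of one another, and among the four compounds only cyclohexyl stands apart. Nothing available here explains why the cyclohexyl compound alone gives the higher number.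

What the compounds shown leave open is where between the cyclobutyl and cyclohexyl rings the number rises, a question that cyclopentyl at this position would address. They also leave open how this position responds to a ring or chain carrying a heteroatom, such as a tetrahydropyranyl ring, an amine or a carboxylic acid, since every group here is made of carbon only.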